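The source may hold more compounds than are shown below. What is called first, only, known or untested is meant among the compounds shown, and "the series" means these compounds.

Measured compounds and their values:

compound 1 `CC(C)n1ncc2c(C(=O)Nc3ccccc3)cccc21`: 11900 nM
compound 2 `CC(C)n1ncc2c(C(=O)NCc3ccccc3)cccc21`: 15200 nM
compound 3 `CC(C)n1ncc2c(C(=O)NCc3cn(-c4ccccc4)nn3)cccc21`: 26000 nM

All three compounds share one core and differ only in the group carried on the amide nitrogen. In a functional assay on PC-3 cells (Homo sapiens) for inhibition, read by MTT assay, with a stated time of 72 h (a lower number here means a stronger inhibitor, a higher number a weaker inhibitor), compound 3 gives 26000 nM, the highest of the three numbers. Its nearest neighbour is compound 2, whose value lies within the scatter of the value of compound 3, so the two cannot be told apart. Its furthest neighbour is compound 1, whose number is lower by more than the scatter, so compound 3 is the weaker of these two.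

Among the measured compounds shown here, the one single-point step among the measured compounds is the change a 1.3-fold higher number from compound 1 to compound 2 (0.11 log units; within the scatter), which stays within the scatter.

Compound 4 `Cc1ccc(-n2cc(CNC(=O)c3cccc4c3cnn4C(C)C)nn2)c(C)c1` is not yet measured. It differs from compound 3 by one change: 2,4-dimethylphenyl in place of phenyl on an aromatic nitrogen. For the measured compounds named here, no measured step touches this part of the molecule, so the only guide is that the one measured step stayed within the scatter. A step no larger than the scatter is therefore expected here, in no fixed direction.

For compound 4 the expected value in this assay is 26000 nM, with an expected range from 10000 nM to 65000 nM. This estimate means an expected step of no change at the digits printed from compound 3 to compound 4 (within the scatter).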

Compound 4, half-maximal inhibitory concentration: 10600 nM
Beside the measured number, compound 4's estimate is 2.5-fold (0.39 log units) above it; the range from low to high includes it.
By their numbers in this assay, from the lowest: compounds 4, 1, 2 and 3 (each within the scatter of the next, the first and the last beyond it).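

In this assay, among the compounds shown here, putting 2,4-dimethylphenyl in place of phenyl on the aromatic nitrogen of the five-membered ring gives a 2.5-fold lower number from compound 3 to compound 4 (0.39 log units; beyond the scatter) and is the only step measured in this short series that lies beyond the scatter. For the compounds shown here, the earlier compounds differed only in the group on the amide nitrogen, and the one step read among them stayed within the scatter, so this result adds a second place on the molecule where a small substitution on a phenyl ring can shift the number, even though the step is only modest. Nothing available explains why the number fell with this change.

From the compounds shown here alone, what remains open is whether both methyl groups of the 2,4-dimethylphenyl are needed, or whether a single methyl group would give the same step. It is also unclear how this ring would respond to other substituents, such as a chlorine atom, a methoxy group or an amine, or to replacing the phenyl with a saturated ring such as cyclohexyl.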